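Heteroaryl Amide Swap on a Shared Core: Inactivity Expected

A few compounds are considered here, and "the series" means these few. Any claim that something is new, unique, unknown or untested is made for them only; others in the source may bear on it.

Compound 1 `CCCn1c(NC(=O)c2nccc3ccccc23)nc2cc(C(N)=O)cc(OC)c21` — > 100000 nM
Compound 2 `CCCn1c(NC(=O)c2ccnn2CC)nc2cc(C(N)=O)cc(OC)c21` — > 100000 nM

In an assay for activation of interferon regulatory factor 3 (Homo sapiens), read by a luciferase reporter, with a stated time of 20 h (on this read-out lower numbers stand for an effect already at smaller amounts and higher numbers for an effect only at larger amounts of compound), compound 1 gives > 100000 nM, which is a limit of the assay and not a number. In this assay compound 2 likewise gives > 100000 nM, again a limit. For the measured compounds named here, the step that the two limits leave unreadable from compound 1 to compound 2 therefore cannot be read, and the only evidence on this series is the limit of > 100000 nM in this assay, at which 2 of the 2 values shown sit.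

Compound 3 `CCCn1c(NC(=O)c2cncn2C)nc2cc(C(N)=O)cc(OC)c21` carries the change (1-methyl-1H-imidazol-5-yl in place of 1-ethyl-1H-pyrazol-5-yl on a carbonyl carbon). Going by the values given here, no measured step bears on it, since both compounds shown sit at the limit. With nothing in the data pointing either way, the step from compound 2 to compound 3 is expected to be a number no higher from compound 2 to compound 3 (the limit leaves the size open), that is none beyond the scatter. Compound 3 is therefore estimated at 100000 nM in this assay, with a range from 30000 nM to 300000 nM, and most likely the assay will again report only a limit.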

Compound 3, half-maximal effective concentration: > 100000 nM
Compound 3 ended at the assay's limit; the forecaster's own chance of this, stated with the estimate: 85%; the middle value lies on the limit itself.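

In this assay compound 3 gives > 100000 nM as a limit of the assay and not a number, so the steps to it from compound 1 and compound 2 cannot be read. The compounds shown leave open whether any group on this carbonyl carbon of the shared core gives a measurable value, the only evidence being this: the limit of > 100000 nM in this assay, at which 3 of the 3 values shown sit.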